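This account rests on a few compounds, and the source may have more. Where it says the series, first, only, none or still open, it means among the compounds named here.

In a functional assay on L1210 cells (Mus musculus) for antiproliferative activity, with a stated time of 48 h (on this read-out higher numbers stand for weaker inhibition and lower numbers for stronger inhibition), three compounds that share an alpha-bromoacrylamide group have been measured. Compound 1 `C=C(Br)C(=O)Nc1ccc(/C=C/C(=O)c2ccc(F)cc2)cc1` gives 1600 nM, and compound 2 `C=C(Br)C(=O)Nc1ccc(/C=C/C(=O)c2cccc(OC)c2)cc1` gives 2100 nM. Compound 3 `C=C(Br)C(=O)Nc1ccc(C(=O)/C=C/c2ccccc2)cc1` gives 880 nM, the lowest number of the three. That value lies within the scatter of compound 1 but beyond the scatter of compound 2, so its lead is firm only against compound 2.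

Compound 4 `C=C(Br)C(=O)Nc1ccc(C(=O)/C=C/c2ccccc2OC)cc1` departs from compound 3 at one place: methoxy in place of hydrogen on an aromatic carbon. This puts methoxy in place of hydrogen on an aromatic carbon, ortho to a large group, turning phenyl into 2-methoxyphenyl.

Among the compounds with values here, only one measured step bears on this change, and only loosely. The step of a 1.3-fold higher number from compound 1 to compound 2 (0.12 log units; within the scatter) also brings in a methoxy group, as 3-methoxyphenyl in place of 4-fluorophenyl on a carbonyl carbon, and it stays within the scatter. Within the data shown here, no measured compound carries methoxy at the place changed in compound 4, so the data give no direction for this change. No shift beyond the scatter is therefore expected in this assay. The estimate amounts to a 1.0-fold higher number from compound 3 to compound 4 (0.01 log units; within the scatter), an expected step that stays within the scatter. For compound 4 the expected value is 900 nM, with an estimated range of 320 nM to 2500 nM.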

Compound 4, half-maximal inhibitory concentration: 1700 nM
Beside the measured number, compound 4's estimate is 1.9-fold (0.28 log units) below it; measured number inside the range.
By their numbers in this assay, from the lowest: compounds 3, 1, 4 and 2 (each within the scatter of the next, the first and the last beyond it).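

In this assay, the step to the 2-methoxyphenyl group is a 1.9-fold higher number from compound 3 to compound 4 (0.29 log units; within the scatter), the only reading shown for a group other than hydrogen at this place, ortho to a large group. It shows that methoxy in place of hydrogen can stand here without a shift beyond the scatter, so this single change gives no firm loss or gain in antiproliferative activity. Nothing available explains the size of this step or says why the number stays within the scatter.

The compounds shown leave open whether other groups at this same place, such as a hydroxyl, an amine or a carboxylic acid, would also stay within the scatter or would move the number further. Within the data shown here, they also leave open whether methoxy at another place on this ring would read the same way, and with only one step at this place, the direction of the change remains unsettled.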